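One Substituent Swap on a Shared Core

A few compounds are considered here, and "the series" means these few. Any claim that something is new, unique, unknown or untested is made for them only; others in the source may bear on it.

Compound 1 `C#CCOc1ccc2c(=O)c(-c3cc(OC)c(OC)cc3OC)coc2c1`: in a functional assay on HUVEC cells (Homo sapiens) for antiproliferative activity, read by MTT assay, with a stated time of 24 h (on this read-out lower numbers stand for stronger inhibition and higher numbers for weaker inhibition), compound 1 gives > 10000 nM, a limit of the assay.
Compound 2 `COc1cc(OC)c(-c2coc3cc(OCc4ccccc4F)ccc3c2=O)cc1OC`: in this assay compound 2 gives 4300 nM.
Compound 3 `COc1cc(OC)c(-c2coc3cc(OCc4ccc([N+](=O)[O-])cc4)ccc3c2=O)cc1OC`: in this assay compound 3 gives > 10000 nM, a limit of the assay.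

Compound 2 holds the only number shown in this assay; the other two values are limits. Two measured steps reach it. The first is an at least 2.3-fold lower number from compound 1 to compound 2 (0.36 log units; beyond the scatter). The second is an at least 2.3-fold higher number from compound 2 to compound 3 (0.36 log units; beyond the scatter). The third measured step is a step that the two limits leave unreadable from compound 1 to compound 3. Both limits rest on (the limit of > 10000 nM in this assay, at which 2 of the 3 values shown sit).

Compound 4 `COc1cc(OC)c(-c2coc3cc(OCc4ccc(C(F)(F)F)cc4)ccc3c2=O)cc1OC` is not yet measured. It differs from compound 2 in one place: 4-(trifluoromethyl)phenyl in place of 2-fluorophenyl on a saturated chain carbon bound to an oxygen on an aromatic ring. The nearest measured step, from compound 2 to compound 3, also replaced 2-fluorophenyl by a phenyl bearing a group in its 4-position, and the number rose to the limit. On that basis compound 4 is expected to give a higher number than compound 2 in this assay, with a real chance of reaching the limit. The expected step is a 2.1-fold higher number from compound 2 to compound 4 (0.32 log units; beyond the scatter). Compound 4 is estimated at 9000 nM, between 3000 nM and 30000 nM.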

Compound 4, half-maximal inhibitory concentration: > 10000 nM
Compound 4: no number, only a limit; the forecaster's own chance of this, stated with the estimate: 50%; at least 1.1-fold (0.04 log units) between middle value and limit.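

In this assay, replacing 2-fluorophenyl by 4-(trifluoromethyl)phenyl on the saturated chain carbon gives an at least 2.3-fold higher number from compound 2 to compound 4 (0.36 log units; beyond the scatter). Compound 3 had already shown such a rise with 4-nitrophenyl, so two different groups on the phenyl 4-position now move the value out of the readable range, and compound 2 remains the only compound with a number. The steps among compound 1, compound 3 and compound 4 cannot be read, and any ranking of these three stays closed, as each of them gives only a limit: the limit of > 10000 nM in this assay, at which 3 of the 4 values shown sit.

The compounds shown leave open whether the fluorine of compound 2 matters at all, since compound 2 is compared only with phenyl groups that differ both in the substituent and in its place. A plain benzyl group, or a benzyl group carrying an amine or a carboxylic acid, would test how far the number depends on that substituent.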